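The source may hold more compounds than are shown below. What is called first, only, known or untested is meant among the compounds shown, and "the series" means these compounds.

Three compounds of the shared core carry different groups on the indole nitrogen side chain. In a functional assay on MDA-MB-231 cells (Homo sapiens) for cytotoxicity, read by MTT assay, with a stated time of 72 h (on this read-out higher numbers stand for weaker inhibition and lower numbers for stronger inhibition), compound 1 `O=C1c2c[n+]([O-])c3ccccc3c2C(=O)c2c1c1ccccc1n2Cc1cn([C@H]2C[C@H](O)[C@@H](CO)O2)nn1` gives 580 nM, compound 2 `O=C1c2c[n+]([O-])c3ccccc3c2C(=O)c2c1c1ccccc1n2Cc1cn(CC(O)CO)nn1` gives 1290 nM and compound 3 `O=C1c2c[n+]([O-])c3ccccc3c2C(=O)c2c1c1ccccc1n2CCCCN1CCNCC1` gives 3310 nM. Compound 2 therefore stands second highest of the three numbers, with compound 1 its nearest neighbour and compound 3 furthest from it; the step of a 2.2-fold higher number from compound 1 to compound 2 (0.35 log units; beyond the scatter) and the step of a 2.6-fold higher number from compound 2 to compound 3 (0.41 log units; beyond the scatter) are both modest but beyond the scatter.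

Compound 4 `O=C1c2c[n+]([O-])c3ccccc3c2C(=O)c2c1c1ccccc1n2Cc1cn([C@@H]2O[C@H](CO)[C@@H](O)[C@H](O)[C@H]2O)nn1` differs from compound 2 by 3,4,5-trihydroxy-6-(hydroxymethyl)oxan-2-yl in place of 2,3-dihydroxypropyl on an aromatic nitrogen. The step that bears on this is a 2.2-fold higher number from compound 1 to compound 2 (0.35 log units; beyond the scatter), where the cyclic 4-hydroxy-5-(hydroxymethyl)oxolan-2-yl gave the lower number than the open 2,3-dihydroxypropyl; compound 4 returns to a ring bearing hydroxyl groups on the triazole nitrogen, so a modest step back toward a lower number in this assay is expected, with a 1.8-fold lower number from compound 2 to compound 4 (0.27 log units; within the scatter) as the estimated size. Compound 4 is accordingly expected at 700 nM, within a range of 300 nM to 1600 nM.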

Compound 4, half-maximal inhibitory concentration: 650 nM
The estimate for compound 4 lay 1.1-fold (0.03 log units) above the measured number; low and high end bracket the measured number.
By their numbers in this assay, from the lowest: compounds 1, 4 and 2 (each within the scatter of the next, the first and the last beyond it); then compound 3.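

On the aromatic nitrogen of the five-membered aromatic ring with 3 nitrogen, replacing the 4-hydroxy-5-(hydroxymethyl)oxolan-2-yl ring with the larger 3,4,5-trihydroxy-6-(hydroxymethyl)oxan-2-yl ring gives a 1.1-fold higher number from compound 1 to compound 4 (0.05 log units; within the scatter) in this assay, so this position does not separate the two rings. Against the open 2,3-dihydroxypropyl, the new ring gives a 2.0-fold lower number from compound 2 to compound 4 (0.30 log units; within the scatter), while the other ring gives a 2.2-fold higher number from compound 1 to compound 2 (0.35 log units; beyond the scatter), so the open chain stands clearly apart from only one of the two rings. No measurement at hand explains this reading.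

Going by these compounds, whether the ring itself or its hydroxyl groups govern the number remains open, and a plain cyclohexyl ring on the same nitrogen would test this. A carboxylic acid or a primary amine at this position would show whether groups other than hydroxyl are tolerated.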